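The source may hold more compounds than are shown below. What is called first, only, known or untested is meant among the compounds shown, and "the series" means these compounds.

Measured so far:
compound 1 `N#CCCCn1c(Cn2c(=O)n(-c3ncco3)c3ccncc32)cc2cc(Cl)ccc21`: > 50000 nM
compound 2 `O=c1n(Cc2nc3ncccc3n2CCCCO)c2cnccc2n1C1CC1`: > 100000 nM
compound 3 `CS(=O)(=O)CCCn1c(Cn2c(=O)[nH]c3ccncc32)cc2cc(Cl)ccc21`: > 50000 nM

In an ADME assay on HeLa cells (Homo sapiens) for cytotoxicity, read by ATP content, with a stated time of 3 days (on this read-out higher numbers stand for lower toxicity in this test and lower numbers for higher toxicity in this test), compound 1 gives > 50000 nM, which is a limit of the assay rather than a number. Compound 2 gives > 100000 nM, also a limit. Compound 3 gives > 50000 nM, a limit as well. Compound 1 thus sits at the limit of > 50000 nM in this assay, at which 2 of the 3 values shown sit. Compound 2 sits at the limit of > 100000 nM in this assay, at which 1 of the 3 values shown sits. Every value shown is a limit. Among the measured compounds shown here, no step between measured compounds can be sized. Compound 4 `N#CCCCn1c(Cn2c(=O)n(-c3ccc(OC(F)(F)F)cc3)c3ccncc32)cc2cc(Cl)ccc21` differs from compound 1 in one place: 4-(trifluoromethoxy)phenyl in place of 1,3-oxazol-2-yl on an aromatic nitrogen. For the measured compounds named here, with no measured step to lean on, the expectation in this assay is no change beyond the scatter, with some chance of a move toward higher toxicity. Compound 4 is expected to give 40000 nM (range 10000 nM to 100000 nM). The step of an at least 1.2-fold lower number from compound 1 to compound 4 (0.09 log units; that floor lies within the scatter) is an estimate, not a measurement.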

Compound 4, half-maximal cytotoxic concentration: > 50000 nM
Compound 4: no number, only a limit (the forecaster's own chance of this, stated with the estimate: 55%); middle value at least 1.2-fold (0.09 log units) from the limit.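

In this assay, among the compounds shown here, compound 1 and compound 4 both give only a limit of the assay, not a number, so no step between them can be read. The compounds shown leave open whether 4-(trifluoromethoxy)phenyl and 1,3-oxazol-2-yl differ at all on this read-out.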